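Replacing the 2,4,6-trimethylphenyl group of compound 3

The compounds below may be only part of what the source reports. "The series", "measured", "known", "first", "only" and "open" are said of these compounds alone.

In a functional assay on K562 cells (Homo sapiens) for cytotoxicity, read by MTT assay, with a stated time of 48 h (a lower number here means a stronger inhibitor, a higher number a weaker inhibitor), compound 1 (`O=C(CN[C@H]1CCN(S(=O)(=O)Cc2ccccc2)C1)N1CCN(Cc2ccc(F)cc2)CC1`) gives 14300 nM, compound 2 (`O=C(CN[C@H]1CCN(S(=O)(=O)Cc2ccccc2)C1)N1CCN(Cc2cccc(C(F)(F)F)c2)CC1`) gives 3600 nM, and compound 3 (`Cc1cc(C)c(CN2CCN(C(=O)CN[C@H]3CCN(S(=O)(=O)Cc4ccccc4)C3)CC2)c(C)c1`) gives 3300 nM. Compound 3 thus stands level with compound 2, with a 1.1-fold lower number from compound 2 to compound 3 (0.04 log units; within the scatter). Compound 4 (`O=C(CN[C@H]1CCN(S(=O)(=O)Cc2ccccc2)C1)N1CCN(Cc2c(F)cccc2Cl)CC1`) carries 2-chloro-6-fluorophenyl in place of 2,4,6-trimethylphenyl on a saturated chain carbon bound to an amine nitrogen in a ring. For the measured compounds named here, compound 1 is the only measured compound with a halogen directly on the ring, and the modest steps away from it were a 4.0-fold lower number from compound 1 to compound 2 (0.60 log units; beyond the scatter) and a 4.3-fold lower number from compound 1 to compound 3 (0.64 log units; beyond the scatter). Part of that size is expected to return in the opposite direction. The expected change is a 2.0-fold higher number from compound 3 to compound 4 (0.29 log units; within the scatter). Compound 4 is estimated at 6500 nM, within a range of 2800 nM to 14000 nM.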

Compound 4, half-maximal inhibitory concentration: 65800 nM
The estimate for compound 4 lay 10-fold (1.01 log units) below the measured number, outside the stated range (above it).
By their numbers in this assay, from the lowest: compounds 3 and 2 (each within the scatter of the next); then compound 1; then compound 4.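

In this assay the 2-chloro-6-fluorophenyl group places compound 4 last of the four compounds, well apart from the two lowest (a 20-fold higher number from compound 3 to compound 4 (1.30 log units; beyond the scatter)) and (an 18-fold higher number from compound 2 to compound 4 (1.26 log units; beyond the scatter)). The number also rises against the other compound with a halogen directly on the ring (a 4.6-fold higher number from compound 1 to compound 4 (0.66 log units; beyond the scatter)). Among these four compounds, then, the halogen-bearing rings give the two highest numbers, and this position proves far less tolerant of change than the earlier compounds showed.

Nothing available accounts for the size of this rise. As far as these compounds go, whether it follows the chlorine, the fluorine or the pair stays open, as does how a methoxy group or a nitrile on this ring would read.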